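From 4-hydroxyphenyl to 2-chlorophenyl: the step to compound 3

The compounds below may be only part of what the source reports. "The series", "measured", "known", "first", "only" and "open" are said of these compounds alone.

Compound 1 `CC1=CC[C@@H]([C@@](C)(O)CCCC(C)(C)NC(=S)N/N=C\c2ccc(C)cc2)CC1` gives 11600 nM
Compound 2 `CC1=CC[C@@H]([C@@](C)(O)CCCC(C)(C)NC(=S)N/N=C\c2ccc(O)cc2)CC1` gives 8870 nM

Going by the values given here, in a functional assay on UACC-62 cells (Homo sapiens) for cytotoxicity, read by sulforhodamine B assay (on this read-out higher numbers stand for weaker inhibition of growth and lower numbers for stronger inhibition of growth), compound 2 gives 8870 nM and stands within the scatter of the only other measured number. Compound 3 `CC1=CC[C@@H]([C@@](C)(O)CCCC(C)(C)NC(=S)N/N=C\c2ccccc2Cl)CC1` differs from it by 2-chlorophenyl in place of 4-hydroxyphenyl on a carbon with a double bond to nitrogen. Among the compounds with values here, the one measured step that bears on this change is a 1.3-fold lower number from compound 1 to compound 2 (0.12 log units; within the scatter) for hydroxy in place of methyl on an aromatic carbon. Within the data shown here, no measured compound carries 2-chlorophenyl, so the expectation is weakly founded and no shift beyond the scatter is expected in this assay in either direction. For compound 3 the expected step is a 1.1-fold lower number from compound 2 to compound 3 (0.04 log units; within the scatter) and so stays small. Compound 3 is estimated at 8000 nM (range 3000 nM to 20000 nM).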

Compound 3, concentration for 50% growth inhibition: 53300 nM
Compound 3: the middle estimate sits 6.7-fold (0.82 log units) below what was measured; measured number outside the range, above it.
By their numbers in this assay, from the lowest: compounds 2 and 1 (each within the scatter of the next); then compound 3.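

In this assay, the group on a carbon with a double bond to nitrogen proves less tolerant than the earlier pair suggested: 2-chlorophenyl in place of 4-hydroxyphenyl gives a 6.0-fold higher number from compound 2 to compound 3 (0.78 log units; beyond the scatter), and 2-chlorophenyl in place of 4-methylphenyl gives a 4.6-fold higher number from compound 1 to compound 3 (0.66 log units; beyond the scatter). Both steps mean weaker inhibition of growth, and they are the first shown at this position to lie beyond the scatter. Nothing measured here accounts for this loss.

As far as these compounds go, whether it follows the chlorine itself or where the chlorine sits remains open. How 4-chlorophenyl or 2-methoxyphenyl would behave at this position is also unknown.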